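The source may hold more compounds than are shown below. What is called first, only, known or untested is meant among the compounds shown, and "the series" means these compounds.

Working notes on the series. Compound 1 `NC1=NC2(CCOCC2)N(OCCCOc2cc(Cl)c(Cl)cc2Cl)C(N)=N1` gives 2750 nM in a functional assay on HCT-116 cells (Homo sapiens) for antiproliferative activity, read by MTT assay, with a stated time of 72 h; on this read-out higher numbers stand for weaker inhibition and lower numbers for stronger inhibition. Compound 2 `Cc1ccc(OCCCON2C(N)=NC(N)=NC23CCOCC3)cc1` gives 2390 nM, and the step of a 1.2-fold lower number from compound 1 to compound 2 (0.06 log units; within the scatter) shows that exchanging the aryl group on the oxygen on the saturated carbon leaves the number essentially unchanged in this pair. Compound 3 `NC1=NC2(CCSCC2)N(OCCCOc2ccc(Cl)cc2)C(N)=N1`, which carries the sulfur-containing core, gives 10 nM; this is the lowest of the three numbers, and its distance from both compound 2 and compound 1 lies well beyond the scatter.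

The next member is compound 4 `COc1ccc(OCCCON2C(N)=NC(N)=NC23CCSCC3)cc1`, which differs from compound 3 by methoxy in place of chloro on an aromatic carbon: a chloro leaves and a methoxy enters, 4-chlorophenyl becoming 4-methoxyphenyl. Among the compounds with values here, the only measured step touching the aryl substituent is the one from compound 1 to compound 2, and that one was within the scatter, although it was taken on the oxygen-containing core with a different pattern of substituents. Within the data shown here, no step on the sulfur-containing core is available. The expectation for compound 4 is therefore a step of a 2.0-fold higher number from compound 3 to compound 4 (0.30 log units; within the scatter) that is small, possibly a slightly higher number, but not clearly beyond the scatter. Compound 4 is estimated at 20 nM, with a range from 6 nM to 80 nM.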

Compound 4, half-maximal inhibitory concentration: 70 nM
The estimate for compound 4 lay 3.5-fold (0.54 log units) below the measured number; the measured number falls inside the stated range.
By their numbers in this assay, from the lowest: compound 3; then compound 4; then compounds 2 and 1 (each within the scatter of the next).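

In this assay, the exchange on the aromatic carbon para to a large group gives a 7.0-fold higher number from compound 3 to compound 4 (0.85 log units; beyond the scatter), so on the core of compound 3 the number responds to the substituent at this position, and methoxy in place of chloro moves it beyond the scatter. Within the data shown here, the only earlier step on the aryl group, a 1.2-fold lower number from compound 1 to compound 2 (0.06 log units; within the scatter), stayed within the scatter, but it was read on a different core with a different aryl pattern, so the pair shows that a change on this aryl group need not leave the number unchanged and gives no single rule for both cores. No measurement at hand accounts for the size of the new step.

It remains open whether the exchange of chloro for methoxy moves the number by a similar amount on the core of compound 1; no pair shown carries the same aryl group on both cores. Also open, going by these compounds, is where other groups at this place, such as an amine, a nitrile or a carboxylic acid, would stand relative to chloro and methoxy.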